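Cyano for carbamoyl on the benzyl arm: cytotoxicity notes

The source may report more compounds than this note shows. Statements on the series, on what has been measured and on what is new or still open speak of the compounds shown alone.

Measured so far in a toxicity assay on MDCK cells (Canis lupus familiaris) for cytotoxicity, read by crystal violet staining, with a stated time of 48 h; on this read-out higher numbers stand for lower toxicity in this test and lower numbers for higher toxicity in this test:
- compound 1 `Cc1ccc2[nH]c(=O)c(CN(Cc3ccc(F)cc3)Cc3ccc(C(C)(C)C)cc3)cc2c1`: > 27000 nM, a limit of the assay.
- compound 2 `Cc1ccc2[nH]c(=O)c(CN(Cc3ccc(OCC(=O)O)cc3)Cc3ccc(C(C)(C)C)cc3)cc2c1`: > 10000 nM, a limit of the assay.
- compound 3 `Cc1ccc2[nH]c(=O)c(CN(Cc3ccc(C(N)=O)cc3)Cc3ccc(C(C)(C)C)cc3)cc2c1`: > 5000 nM, a limit of the assay.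

Compound 3 stands at a limit, as do its two neighbours; none of the three values is a number. The measured steps accordingly carry no size: a step that the two limits leave unreadable from compound 1 to compound 2, a step that the two limits leave unreadable from compound 1 to compound 3 and a step that the two limits leave unreadable from compound 2 to compound 3. Going by the values given here, the only evidence is the set of limits themselves, (the limit of > 27000 nM in this assay, at which 1 of the 3 values shown sits), the limit of > 10000 nM in this assay, at which 1 of the 3 values shown sits, and (the limit of > 5000 nM in this assay, at which 1 of the 3 values shown sits), which together show no cytotoxicity resolved by this test for any member of the series so far.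

Compound 4 `Cc1ccc2[nH]c(=O)c(CN(Cc3ccc(C#N)cc3)Cc3ccc(C(C)(C)C)cc3)cc2c1` carries the next change on the same arm: cyano in place of carbamoyl on an aromatic carbon. Among the compounds with values here, no measured step bears on this change in a readable way, so no direction can be derived from the series. The expectation for compound 4 in this assay is therefore simply a further limit, with an estimated step that the limit leaves unreadable from compound 3 to compound 4. The estimate for compound 4 is 30000 nM, with a range from 10000 nM to 100000 nM.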

Compound 4, half-maximal cytotoxic concentration: > 5000 nM
Compound 4 ended at the assay's limit (the forecaster's own chance of this, stated with the estimate: 80%); the middle value does not contradict the limit.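

In this assay compound 4 gives > 5000 nM as a limit of the assay. Its steps from compounds 1, 2 and 3 cannot be read. The compounds shown leave open where the half-maximal cytotoxic concentration of any of the four lies, and whether fluoro, carboxymethoxy, carbamoyl and cyano differ at all on this arm.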